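This account rests on a few compounds, and the source may have more. Where it says the series, first, only, none or still open, it means among the compounds named here.

Measured compounds in a functional assay on A-375 cells (Homo sapiens) for cytotoxicity, read by MTT assay, with a stated time of 72 h, tested at 10 uM; on this read-out higher numbers stand for more inhibition of growth at the one concentration tested and lower numbers for less inhibition of growth:

- compound 1 `N/C(=N\NC(=S)N1CCOCC1)c1ccccn1`: 18.3%
- compound 2 `Cc1ccnc(/C(N)=N/NC(=S)N2CCOCC2)c1`: 86%
- compound 3 `N/C(=N\NC(=S)N1CCCCCC1)c1ccc(F)cn1`: 72.2%

Among these three, compound 2 stands highest in this assay; compound 3 comes nearest, and compound 1 lies furthest away. Going by the values given here, the one single-place step that has been measured runs from compound 1 to compound 2, where a methyl in place of hydrogen on an aromatic carbon gave a number 67.7 percentage points higher from compound 1 to compound 2 (beyond the scatter).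

Compound 4 `Cc1ccnc(/C(N)=N/NC(=S)N2CCCC2)c1` keeps everything in compound 2 except one change: pyrrolidin-1-yl in place of morpholin-4-yl on a thiocarbonyl carbon. Among the compounds with values here, no measured pair differs in exactly this way, so no step bears directly on it. Compound 3 does carry a different ring on the thiocarbonyl carbon, but it also has a different aromatic part, so its value of 72.2% only shows that such a combination still gives a high number; it cannot be split into the two changes.

With no direct guide, the expectation for compound 4 rests on compound 2 as the starting point, with room for a moderate drop or little change. The step from compound 2 to compound 4 is therefore estimated at a number 12 percentage points lower from compound 2 to compound 4 (beyond the scatter). On this basis compound 4 is expected to give about 74% in this assay, within a range from 45% to 95%.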

Compound 4, percent growth inhibition at one concentration: 86%
For compound 4 the middle estimate is 12 percentage points below the measured one; measured number inside the range.
By their numbers in this assay, from the lowest: compound 1; then compound 3; then compounds 2 and 4 (each within the scatter of the next).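

Held on the same methyl-bearing aromatic part, pyrrolidin-1-yl in place of morpholin-4-yl on a thiocarbonyl carbon gave no change at the digits printed from compound 2 to compound 4 (within the scatter) in this assay. Going by these compounds alone, this is the first direct reading of this position, and it shows that, on this core, the six-membered ring with its oxygen can give way to the five-membered ring with no hetero atom other than its nitrogen, while the read-out stays where it was. Nothing measured here gives a reason for this outcome.

From the compounds shown here alone, both compounds carry the methyl group, so it remains open whether the same ring exchange would read alike on the unmethylated aromatic part of compound 1, which stands at 18.3%. A piperazin-1-yl ring or an open-chain diethylamino group on the same thiocarbonyl carbon lies outside the compounds shown, so what either would give in this assay also remains open.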